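Trading a Sulfonamide Arm for a Pentylphenyl Group

This account rests on a few compounds, and the source may have more. Where it says the series, first, only, none or still open, it means among the compounds named here.

Compound 1 `Cc1ccc(S(=O)(=O)NCc2cn(C[C@H](O)[C@H]3OC(=O)C(OCc4ccccc4)=C3OCc3ccccc3)nn2)cc1` gives 50 nM in an ADME assay on HFF cells (Homo sapiens) for cytotoxicity, read by MTT assay, with a stated time of 72 h; on this read-out lower numbers stand for stronger inhibition and higher numbers for weaker inhibition.
Compound 2 `O=C1O/C(=C\Cn2cc(-c3cc(F)cc(F)c3)nn2)C(OCc2ccccc2)=C1OCc1ccccc1` reaches only a limit of the assay, > 100000 nM.
Compound 3 `COc1ccccc1-c1cn(C/C=C2\OC(=O)C(OCc3ccccc3)=C2OCc2ccccc2)nn1` likewise reaches only a limit, > 100000 nM.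

For the measured compounds named here, compound 1 therefore holds the only real number here; the other two values sit at the limit of > 100000 nM in this assay, at which 2 of the 3 values shown sit. Going by the values given here, the one step among measured compounds, a step that the two limits leave unreadable from compound 2 to compound 3, cannot be read, so no measured step bears directly on what follows. Compound 4 `CCCCCc1ccc(-c2cn(C[C@H](O)[C@H]3OC(=O)C(OCc4ccccc4)=C3OCc3ccccc3)nn2)cc1` differs from compound 1 by 4-pentylphenyl in place of (((4-methylphenyl)sulfonyl)amino)methyl on an aromatic carbon. Compounds 2 and 3, which also carry an aryl group on the same ring, both sit at the limit, so weaker inhibition is expected, with wide uncertainty: the estimated step is a 60-fold higher number from compound 1 to compound 4 (1.78 log units; beyond the scatter). Compound 4 is expected to give 3000 nM, between 100 nM and 100000 nM.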

Compound 4, half-maximal inhibitory concentration: > 100000 nM
Compound 4: no number, only a limit; the forecaster's own chance of this, stated with the estimate: 30%; middle value at least 33-fold (1.52 log units) away from the limit.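

For the compounds shown here, at this aromatic carbon, 4-pentylphenyl in place of (((4-methylphenyl)sulfonyl)amino)methyl gives the first readable step: an at least 2000-fold higher number from compound 1 to compound 4 (3.30 log units; beyond the scatter). Compound 4 keeps the rest of compound 1 unchanged, so the shared core alone does not give a measurable cytotoxic value when it carries this aryl group. The step is only a minimum, since compound 4 reaches a limit of the assay and not a number: the limit of > 100000 nM in this assay, at which 3 of the 4 values shown sit.

Which part of the sulfonamide arm matters remains open: the sulfonyl, the amino hydrogen or the 4-methylphenyl ring. Also open, as far as these compounds go, is whether a simple amine or a carboxylic acid at this carbon would bring back a real number.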